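The source may report more compounds than this note shows. Statements on the series, on what has been measured and on what is new or still open speak of the compounds shown alone.

Measured compounds:
- compound 1, `Nc1nc(O)nc2ccccc12`: 4.02
- compound 2, `Nc1nc(S)c2cc(S(=O)(=O)c3ccc4ccccc4c3)ccc2n1`: 7.6

In an assay for inhibition of Dihydrofolate reductase (Homo sapiens) (a lower number here means a less potent compound, a higher number a more potent compound, by a factor of ten per unit of this negative logarithm), compound 1 gives 4.02. In this assay compound 2 gives 7.6, the highest of the two numbers recorded; the nearest value is that of compound 1, which lies lower by an amount beyond the usual scatter. For the measured compounds named here, no step between compounds differing in a single place is recorded, so compounds 1 and 2, which differ in several places at once, show only their two values and nothing about any one change.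

Compound 3, `Nc1nc(O)c2cc(S(=O)(=O)c3ccc4ccccc4c3)ccc2n1`, is yet to be measured in this assay. It differs from compound 2 in one place: hydroxy in place of sulfanyl on an aromatic carbon. The change sits on an aromatic carbon of a six-membered aromatic ring with two nitrogens, part of a fused system of two rings.

Going by the values given here, because compound 1, the only compound carrying hydroxy at the corresponding place, gives 4.02, while compound 2 gives 7.6, a step downward of moderate size is expected, a number 0.80 log units lower from compound 2 to compound 3 (beyond the scatter), though those two compounds differ elsewhere as well. Compound 3 is estimated at 6.8, within 6 to 7.5.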

Compound 3, logarithm of the reciprocal of the active concentration, log(1/C): 7.96
Compound 3: the middle estimate sits 1.16 log units below what was measured; the measured number lies above the stated range.
By their numbers in this assay, from the lowest: compound 1; then compound 2; then compound 3.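

In this assay, hydroxy in place of sulfanyl on an aromatic carbon, next to the ring nitrogen, gives a number 0.36 log units higher from compound 2 to compound 3 (beyond the scatter), a modest step that shows this position keeps its high number with hydroxy in place and even gains a little. The low number of compound 1 therefore cannot be read as a mark of hydroxy alone: compound 1 gives 4.02 and compound 3, with hydroxy at the corresponding place, gives 7.96, so the same group stands on both the lowest and the highest of the three numbers. No measurement at hand offers an explanation for the step from sulfanyl to hydroxy.

With only sulfanyl and hydroxy compared at this position, the compounds shown leave open how an amine, a methoxy group or a plain hydrogen would fare there. They also leave open whether the exchange of sulfanyl for hydroxy would give a step of similar size and direction on the core of compound 1, or with a different group in place of the rest of compound 3.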